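A few compounds are considered here, and "the series" means these few. Any claim that something is new, unique, unknown or untested is made for them only; others in the source may bear on it.

Of the compounds shown here, three sharing one core have been tested in an ADME assay on cells for inhibition of Amine oxidase [flavin-containing] A (Homo sapiens), read by spectrophotometry; on this read-out higher numbers stand for weaker inhibition and lower numbers for stronger inhibition. Compound 1 `S=C(Nc1ccccc1)Nc1ccc2[nH]ccc2c1` gives > 30000 nM, which is a limit of the assay rather than a number. Compound 2 `Oc1ccccc1NC(=S)Nc1ccc2[nH]ccc2c1` gives 39000 nM, the only number shown. Compound 3 `O=C(c1ccccc1)c1ccc(NC(=S)Nc2ccc3[nH]ccc3c2)cc1` is reported as "not active" (no number reported). The step that the limit leaves unreadable from compound 1 to compound 2 brings in a hydroxy group but cannot be read because compound 1 sits at the limit of > 30000 nM in this assay, at which 1 of the 3 values shown sits. Compound 4 `Cc1ccc(NC(=S)Nc2ccc3[nH]ccc3c2)c(O)c1` differs from compound 2 by methyl in place of hydrogen on an aromatic carbon. Among the measured compounds shown here, no measured step shows what such a methyl does here, so no change beyond the scatter is expected, and the estimated step is a 1.0-fold higher number from compound 2 to compound 4 (0.01 log units; within the scatter). Compound 4 is therefore expected to give 40000 nM in this assay, within a range from 15000 nM to 110000 nM.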

Compound 4, half-maximal inhibitory concentration: "not active" (no number reported)
Nothing numeric was reported for compound 4, so the estimate cannot be set against anything.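

Among the compounds shown here, compound 4 is reported as "not active" (no number reported), so no step from compound 2 to compound 4 can be read. The compounds shown leave open what a methyl on the aromatic ring does to the number in this assay.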